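Imide swap on the benzoate ester series: phthalimide for dimethylsuccinimide

The source may hold more compounds than are shown below. What is called first, only, known or untested is meant among the compounds shown, and "the series" means these compounds.

Measured compounds:
compound 1 `CC1(C)CC(=O)N(c2ccccc2C(=O)OCC2CCCN(CCCc3ccccc3)C2)C1=O`: 4900 nM
compound 2 `O=C(OCC1CCCN(CCCc2ccccc2)C1)c1ccccc1-c1ccccc1`: 13500 nM; 13500 nM (2 entries)
compound 3 `O=C(Nc1ccncn1)c1ccccc1-c1ccccc1`: 25100 nM

In an in vitro functional assay on HEK ts201 cells for antagonist activity at Neuronal acetylcholine receptor; alpha4/beta2 (Homo sapiens), read by fluorescence and calcium flux (a lower number here means a stronger inhibitor, a higher number a weaker inhibitor), compound 1 gives 4900 nM, the lowest of the two single numbers seen so far. Its nearest neighbour is compound 3, which in this assay gives 25100 nM, a higher number beyond the usual scatter. Compound 2 has two entries in this assay rather than one number, both at 13500 nM; 13500 nM (2 entries); set beside compound 1, those entries also show a higher number.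

The next compound, compound 4 `O=C(OCC1CCCN(CCCc2ccccc2)C1)c1ccccc1N1C(=O)c2ccccc2C1=O`, is not yet measured in this assay. Relative to compound 1 it differs in one place:

a group of 11 heavy atoms (8 carbon, 1 nitrogen, 2 oxygen; one five-membered non-aromatic ring with 1 hetero atom, one six-membered aromatic ring of carbon only) in place of a group of 9 heavy atoms (6 carbon, 1 nitrogen, 2 oxygen; one five-membered non-aromatic ring with 1 hetero atom), on an aromatic carbon

The change sits on an aromatic carbon of a six-membered aromatic ring of carbon only, ortho to a large group, and keeps the rest of compound 1 intact. For the measured compounds named here, no measured pair in this set shows a comparable change, so the size of the step cannot be read from the data. Compound 4 is expected to give about 4000 nM, within 1500 nM to 12000 nM. The expected step of a 1.2-fold lower number from compound 1 to compound 4 (0.09 log units; within the scatter) is estimated to stay within the scatter, with no clear direction.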

Compound 4, half-maximal inhibitory concentration: 5010 nM
For compound 4 the middle estimate is 1.3-fold (0.10 log units) below the measured one; the range from low to high includes it.
By their numbers in this assay, from the lowest: compounds 1 and 4 (each within the scatter of the next); then compound 3.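

In this assay, exchanging the 3,3-dimethyl-2,5-dioxopyrrolidin-1-yl group for the imide that carries an added six-membered aromatic ring of carbon only amounts to a 1.0-fold higher number from compound 1 to compound 4 (0.01 log units; within the scatter), so the two imides cannot be told apart here. For the compounds shown here, no earlier pair differed in one place, and this is the first direct reading at this aromatic carbon, ortho to a large group: a group of 11 heavy atoms and a group of 9 heavy atoms, both with two carbonyls, fit the series equally well on this measure. No measurement is available that explains why the number stays in place.

From the compounds shown here alone, the step covers only two imides, so it remains open whether this position accepts an amine, a carboxylic acid or a methoxy group at the same aromatic carbon, or whether the imide carbonyls matter at all. Going by these compounds, it also remains open whether the two imides stay level when a longer chain replaces the one ending in the phenyl ring in the shared core.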